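The compounds below may be only part of what the source reports. "The series", "measured", "known", "first", "only" and "open" are said of these compounds alone.

Working notes on the series.

Compound 1, `Cc1cc(NC(=O)Cn2nnc(-c3ccccc3)n2)n(C2CCOCC2)n1`, is the reference point. In an assay on HEK293 cells for activation of Kir3.1/Kir3.2 (Homo sapiens), read by thallium flux (a higher number here means that more compound is needed for the effect, a lower number that less compound is needed), compound 1 gives 435 nM. Within the data shown here, this is the only numerical value in the set, so compound 1 stands alone as a measured number, with no other compound to rank it against.

Compound 2, `CC1(c2cc(NC(=O)Cn3nnc(-c4ccccc4)n3)n(C3CCCCC3)n2)CC1`, is also in the set, but in this assay compound 2 returns only a limit, > 10000 nM, not a number. This limit is the limit of > 10000 nM in this assay, at which 1 of the 2 values shown sits. Among the measured compounds shown here, no step between compound 1 and compound 2 is given, and the limit cannot be set beside the number of compound 1 as a measured difference.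

Compound 3, `Cc1cc(NC(=O)Cn2nnc(-c3ccccc3)n2)n(CC2CCCCC2)n1`, has not yet been measured. It differs from compound 1 in one place: cyclohexylmethyl in place of oxan-4-yl on an aromatic nitrogen. The change keeps the shared core and the methyl group and swaps the group on the aromatic nitrogen, cyclohexylmethyl in place of oxan-4-yl.

For the measured compounds named here, no measured step covers this change, so the expectation rests on compound 1 alone. A loss in this assay is expected, of a size a 3.4-fold higher number from compound 1 to compound 3 (0.54 log units; beyond the scatter), beyond the usual scatter. Compound 3 is estimated at 1500 nM, within a range from 300 nM to 8000 nM, with a real chance that this assay reports only a limit for compound 3.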

Compound 3, half-maximal effective concentration: 176 nM
For compound 3 the middle estimate is 8.5-fold (0.93 log units) above the measured one, outside the stated range (below it).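

Among these compounds, at this position on the aromatic nitrogen, the change to cyclohexylmethyl in place of oxan-4-yl gives the first readable step in this assay, a 2.5-fold lower number from compound 1 to compound 3 (0.39 log units; beyond the scatter), and it lies beyond the usual scatter. With the shared core and the methyl group kept, the ring oxygen and the single hydrogen-bond acceptor of oxan-4-yl are therefore not required for a measured value in this assay, and a ring of carbon only, held on a methylene link, is accepted at this nitrogen. Nothing measured in the set gives a reason for this step, so it stands as an observation on one pair of compounds and not as a trend.

Open, as far as these compounds go, is which part of the change carries the step, since compound 3 differs from compound 1 both in the ring oxygen and in the methylene link, and oxan-4-ylmethyl on the same nitrogen would separate the two. Also open, from the compounds shown here alone, is how this position responds to an amine such as piperidin-4-yl, or to a longer chain such as 2-cyclohexylethyl.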